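A few compounds are considered here, and "the series" means these few. Any claim that something is new, unique, unknown or untested is made for them only; others in the source may bear on it.

Measured so far:
compound 1 `O=Cc1cn(-c2ccccc2)nc1-c1ccc([N+](=O)[O-])cc1`, 80%
compound 2 `O=Cc1cn(-c2ccccc2)nc1-c1ccccc1O`, 79%

Both numbers come from a functional assay on MCF7 cells (Homo sapiens) for antiproliferative activity, read by MTT assay, with a stated time of 24 h, tested at 1 ug/mL; on this read-out lower numbers stand for a stronger effect and higher numbers for a weaker effect at the one concentration tested. In this assay compound 1 gives 80% and compound 2 gives 79%; the two lie within the usual scatter of each other, so no order can be read between them. Compound 3 `O=Cc1cn(-c2ccccc2)nc1-c1ccc(Cl)cc1` is not yet measured. It differs from compound 1 in one place: chloro in place of nitro on an aromatic carbon. Among the measured compounds shown here, no measured pair shows a change of this kind, so nothing here fixes its size. The step expected in this assay is no change at the digits printed from compound 1 to compound 3 (within the scatter), none beyond the scatter. Compound 3 is estimated at 80%, with a range from 66% to 92%.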

Compound 3, a percentage reported as activity, at one concentration (the size of the read-out at that concentration, not a potency): 59%
The estimate for compound 3 lay 21 percentage points above the measured number; measured number below the stated range.
By their numbers in this assay, from the lowest: compound 3; then compounds 2 and 1 (each within the scatter of the next).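

Chloro in place of nitro on the aromatic carbon para to a large group gives a number 21 percentage points lower from compound 1 to compound 3 (beyond the scatter) in this assay, a stronger effect at the one concentration tested. Among the compounds shown here, this position therefore affects the read-out, and this is the only step so far. No measurement on hand accounts for the step.

Going by these compounds, how an amine, a methoxy group, a carboxylic acid or bromo would read at this same carbon stays open. On these data alone, a single pair also gives no trend across this position, and the effect of chloro elsewhere on the shared core remains unknown.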